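The compounds below may be only part of what the source reports. "The series", "measured", "known", "first", "only" and "open" are said of these compounds alone.

Measured compounds:
- Compound 1, `O=C1Cc2cc(S(=O)(=O)N3CCNCC3)ccc2N1`: "not active" (no number reported)
- Compound 2, `N#Cc1ccc(N2CCN(S(=O)(=O)c3ccc4c(c3)CC(=O)N4)CC2)cc1`: 2910 nM
- Compound 3, `O=C1Cc2cc(S(=O)(=O)N3CCN(c4ccc(F)cc4)CC3)ccc2N1`: "not active" (no number reported)

In an assay on isolated protein for inhibition of lysosomal alpha-glucosidase (Homo sapiens), read by fluorescence, with stated times of 5 min and 45 min (a lower number here means a stronger inhibitor, a higher number a weaker inhibitor), compound 2 gives the only numbered result of the three; compound 1 and compound 3 returned no number at all. Compound 4, `O=C1Cc2cc(S(=O)(=O)N3CCN(c4ccc(Cl)cc4)CC3)ccc2N1`, is not yet measured. It differs from compound 2 in one place: chloro in place of cyano on an aromatic carbon. Since compound 3, with a fluoro at that same position, gave no number, the step from compound 2 to compound 4 is expected to go toward weaker inhibition, by a margin beyond the usual scatter, and the chance that compound 4 also returns no number is considerable. The expected step is a 3.1-fold higher number from compound 2 to compound 4 (0.49 log units; beyond the scatter). For compound 4 the estimate in this assay is 9000 nM, within 2500 nM to 35000 nM.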

Compound 4, half-maximal inhibitory concentration: 94300 nM
Compound 4: the middle estimate sits 10-fold (1.02 log units) below what was measured; the measured number lies above the stated range.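

In this assay, replacing the nitrile with chloro on this aromatic carbon gives a 32-fold higher number from compound 2 to compound 4 (1.51 log units; beyond the scatter), so inhibition here depends strongly on the group at this position. Compound 4 also gives a measured number with a halogen at this position, whereas compound 3, with fluoro, gave none. No measurement shown explains why the 4-cyanophenyl compound is the stronger inhibitor. From the compounds shown here alone, whether another group at this position, such as an amine, a carboxylic acid or a methoxy group, could match or beat the nitrile remains open.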